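Benzothiophene in place of chlorophenyl on the triazole arm

This account rests on a few compounds, and the source may have more. Where it says the series, first, only, none or still open, it means among the compounds named here.

Measured so far:
Compound 1, `O=C(NO)c1ccc(NCc2nc(-c3ccco3)nn2-c2ccccc2)cc1` — 59.9%
Compound 2, `O=C(NO)c1ccc(NCc2nc(-c3cccc4cnccc34)nn2-c2ccccc2)cc1` — 40.2%
Compound 3, `O=C(NO)c1ccc(NCc2nc(-c3cccc(Cl)c3)nn2-c2ccccc2)cc1` — 61.2%

The three compounds share one core and differ only in the group on the aromatic carbon between two ring nitrogen atoms. In an assay on Sf9 cells for inhibition of protein deacetylase HDAC6 (Homo sapiens), read by fluorescence, with a stated time of 40 min, tested at 100 nM (on this read-out lower numbers stand for less inhibition and higher numbers for more inhibition at the one concentration tested (going by the name of the read-out)), compound 3 gives 61.2%, the highest of the three numbers. Its nearest neighbour is compound 1: the step of a number 1.3 percentage points higher from compound 1 to compound 3 (within the scatter) lies within the scatter, so the two cannot be ranked. Compound 2 is furthest away: a number 21 percentage points higher from compound 2 to compound 3 (beyond the scatter), and likewise a number 19.7 percentage points lower from compound 1 to compound 2 (beyond the scatter).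

Compound 4, `O=C(NO)c1ccc(NCc2nc(-c3cc4ccccc4s3)nn2-c2ccccc2)cc1`, has not yet been measured. Its change from compound 3 is 1-benzothiophen-2-yl in place of 3-chlorophenyl on an aromatic carbon. Among the measured compounds shown here, of the measured steps, only the one from compound 1 to compound 2 bears on it: there a two-ring aromatic group entered in place of a five-membered heteroaromatic ring and the number fell by a modest, beyond-scatter amount. Compound 4 also carries a two-ring group, though it is attached through its five-membered ring, as furan-2-yl is in compound 1. An estimated step of a number 11.2 percentage points lower from compound 3 to compound 4 (beyond the scatter) is therefore expected, a decrease of modest size but with wide uncertainty. Compound 4 is expected to give about 50%, in the range 30% to 68%.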

Compound 4, a percentage reported as inhibition, at one concentration (the size of the read-out at that concentration, not a potency): 65.5%
Compound 4: the middle estimate sits 15.5 percentage points below what was measured, within the range that was stated.
By their numbers in this assay, from the lowest: compound 2; then compounds 1, 3 and 4 (each within the scatter of the next).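

In this assay, the aromatic carbon between two ring nitrogen atoms also takes 1-benzothiophen-2-yl with no readable loss, as shown by a number 4.3 percentage points higher from compound 3 to compound 4 (within the scatter) and by a number 5.6 percentage points higher from compound 1 to compound 4 (within the scatter), so compound 4 cannot be ranked against compound 3 or compound 1. The fall seen with isoquinolin-5-yl therefore does not extend to every two-ring aromatic group at this position, as a number 25.3 percentage points higher from compound 2 to compound 4 (beyond the scatter) shows, and compound 4 is the compound that goes against such a pattern. Nothing available accounts for the gap between these two two-ring groups.

The compounds shown leave open whether a group carrying an amine or a carboxylic acid would be accepted at this position. They also leave open whether compound 3 and compound 4 would separate at concentrations other than the one tested.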